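Same Aryl Swap, Second Core: What to Expect of Compound 4

The source may report more compounds than this note shows. Statements on the series, on what has been measured and on what is new or still open speak of the compounds shown alone.

In a functional assay on A549 cells (Homo sapiens) for cytotoxicity, read by MTT assay, with a stated time of 72 h (on this read-out lower numbers stand for stronger inhibition and higher numbers for weaker inhibition), three compounds have so far been measured:

Compound 1 `Cc1cc(=O)n(-c2ccccc2OC(F)(F)F)nc1C(=O)Nc1ccc(Oc2ncnc3[nH]ccc23)c(F)c1` gives 16200 nM
Compound 2 `Cc1cc(=O)n(-c2ccc(Br)cc2F)nc1C(=O)Nc1ccc(Oc2ncnc3[nH]ccc23)c(F)c1` gives 6120 nM
Compound 3 `Cc1cc(=O)n(-c2ccccc2OC(F)(F)F)nc1C(=O)Nc1ccc(Oc2ncnc3c2ccn3C)cc1` gives 25200 nM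

Compounds 1 and 2 share one core and differ in one place: 4-bromo-2-fluorophenyl in place of 2-(trifluoromethoxy)phenyl on an aromatic nitrogen. That change is accompanied by a 2.6-fold lower number from compound 1 to compound 2 (0.42 log units; beyond the scatter), so on this core the swap brings a modest gain in potency.

Compound 3 carries a second core. How its core differs from that of compound 1 is not broken down here; what the two values show is that compound 3 and compound 1 lie within the usual scatter of each other in this assay, so no order between them can be read.

Compound 4 `Cc1cc(=O)n(-c2ccc(Br)cc2F)nc1C(=O)Nc1ccc(Oc2ncnc3c2ccn3C)cc1` is the counterpart of compound 3 on this second core, and the change from compound 3 to compound 4 is the same one already seen between compounds 1 and 2: 4-bromo-2-fluorophenyl in place of 2-(trifluoromethoxy)phenyl on an aromatic nitrogen. Both changes sit at the same place, described in the same words.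

The expectation for compound 4 therefore rests on a single measured pair. Because compound 2 showed a 2.6-fold lower number from compound 1 to compound 2 (0.42 log units; beyond the scatter) against compound 1, a step of similar size is expected on the second core, namely a 2.6-fold lower number from compound 3 to compound 4 (0.41 log units; beyond the scatter). Among the measured compounds shown here, compound 4 is thus estimated at 9700 nM in this assay, most likely between 4000 nM and 22000 nM, with the wide range reflecting that only one earlier instance of this change is known and that it was measured on a different core.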

Compound 4, half-maximal inhibitory concentration: 47300 nM
Compound 4: middle estimate off by 4.9-fold (0.69 log units), on the low side; measured number outside the range, above it.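

In this assay, placing 4-bromo-2-fluorophenyl where 2-(trifluoromethoxy)phenyl stood on the second core gave a 1.9-fold higher number from compound 3 to compound 4 (0.27 log units; within the scatter), so the gain seen on the first core did not reappear and compound 3 and compound 4 cannot be put in order. The two instances of the change do not agree: the same change on two cores in this assay, a 2.6-fold lower number (0.42 log units; beyond the scatter) from compound 1 to compound 2 and a 1.9-fold higher number (0.27 log units; within the scatter) from compound 3 to compound 4, 5.0-fold (0.70 log units) apart, beyond the scatter of two such steps. Among the compounds shown here, this shows that the step measured on one core cannot be carried to another as a fixed increment, but it does not show that the change works in the opposite direction on the second core, nor which feature of the two cores separates the outcomes, since they differ in more than one place and each offers only a single pair.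

The compounds shown leave open whether the disagreement between the cores holds for other groups on the same aromatic nitrogen, since only these two substituted phenyl groups appear there on both cores. They also leave open how a phenyl carrying an amine or a carboxylic acid at that nitrogen would behave on either core, and whether any such pair would give matching steps.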